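The source may hold more compounds than are shown below. What is called first, only, known or untested is meant among the compounds shown, and "the series" means these compounds.

Compound 1 `Cc1ccccc1C1CC(c2ccc(OCc3ccccc3)cc2)=NN1c1ccc(S(N)(=O)=O)cc1`: 100000 nM
Compound 2 `NS(=O)(=O)c1ccc(N2N=C(c3ccc(Oc4ccccc4)cc3)CC2c2cccc(Cl)c2)cc1`: 88000 nM

In an ADME assay on Vero 76 cells (Chlorocebus sabaeus) for cytotoxicity, read by MTT assay, with a stated time of 96 h (on this read-out lower numbers stand for higher toxicity in this test and higher numbers for lower toxicity in this test), compound 2 gives 88000 nM, which lies within the scatter of compound 1 at 100000 nM. Compound 3 `NS(=O)(=O)c1ccc(N2N=C(c3ccc(OCc4ccccc4)cc3)CC2c2cccc(Cl)c2)cc1` has benzyl in place of phenyl on an oxygen on an aromatic ring. Among the measured compounds shown here, no step between measured compounds is available to calibrate this change. Compound 1, which also carries a benzyloxy group, gives 100000 nM, so no step beyond the scatter is expected in this assay. The expected change is small: a 1.0-fold lower number from compound 2 to compound 3 (0.02 log units; within the scatter). For compound 3 the estimated value is 85000 nM, with an expected range of 40000 nM to 100000 nM.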

Compound 3, half-maximal cytotoxic concentration: 85000 nM
Beside the measured number, compound 3's estimate shows no gap at the digits printed, and the stated range covers the measured number.
By their numbers in this assay, from the lowest: compounds 3, 2 and 1 (each within the scatter of the next).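

In this assay, among the compounds shown here, the swap of phenoxy to benzyloxy on the aromatic ring gives a 1.0-fold lower number from compound 2 to compound 3 (0.02 log units; within the scatter) and so gives the first reading of this change at this position. With benzyloxy kept, 3-chlorophenyl in place of 2-methylphenyl on a saturated ring carbon gives a 1.2-fold lower number from compound 1 to compound 3 (0.07 log units; within the scatter) and also stays within the scatter, so neither place has yet moved this read-out. No measured evidence offers a reason for either step. On these data alone, whether an amine or a carboxylic acid in place of benzyl on that oxygen would shift the number remains open.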